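Aryl swap on the four-membered ring of compound 1

The source may hold more compounds than are shown below. What is called first, only, known or untested is meant among the compounds shown, and "the series" means these compounds.

Measured so far:
compound 1 `COc1cc(N2C(=O)[C@@H](Oc3ccccc3)[C@H]2c2ccc([N+](=O)[O-])cc2)cc(OC)c1OC`: 63000 nM
compound 2 `CCOC(=O)/C=C/c1ccc([C@@H]2[C@H](Oc3ccccc3)C(=O)N2c2cc(OC)c(OC)c(OC)c2)cc1`: 87000 nM

In a functional assay on MCF7 cells (Homo sapiens) for antiproliferative activity, read by MTT assay, with stated times of 24 h and 72 h (a higher number here means a weaker inhibitor, a lower number a stronger inhibitor), compound 1 gives 63000 nM and compound 2 gives 87000 nM. Compound 1 is the starting point here, and the two numbers shown lie within the scatter of each other: the step of a 1.4-fold higher number from compound 1 to compound 2 (0.14 log units; within the scatter) is the only measured step in the set, and it was the replacement of the nitro group on an aromatic carbon by another group.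

Compound 3 `COc1ccc([C@@H]2[C@H](Oc3ccccc3)C(=O)N2c2cc(OC)c(OC)c(OC)c2)cc1N` is not yet measured. It differs from compound 1 by 3-amino-4-methoxyphenyl in place of 4-nitrophenyl on a saturated ring carbon. Among the measured compounds shown here, the one measured step that bears on this change, a 1.4-fold higher number from compound 1 to compound 2 (0.14 log units; within the scatter), also altered the group on that aryl ring and did not move the number beyond the scatter. No step beyond the scatter is therefore expected for compound 3, that is a 1.1-fold higher number from compound 1 to compound 3 (0.05 log units; within the scatter). Compound 3 is estimated at 70000 nM, with a range of 25000 nM to 200000 nM.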

Compound 3, half-maximal inhibitory concentration: 12200 nM
Compound 3: middle estimate off by 5.7-fold (0.76 log units), on the high side; measured number below the stated range.
By their numbers in this assay, from the lowest: compound 3; then compounds 1 and 2 (each within the scatter of the next).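

In this assay, the group on the saturated ring carbon next to the ring nitrogen can move the number beyond the scatter: 3-amino-4-methoxyphenyl in place of 4-nitrophenyl gives a 5.2-fold lower number from compound 1 to compound 3 (0.71 log units; beyond the scatter). The earlier change on this aryl ring gave only a 1.4-fold higher number from compound 1 to compound 2 (0.14 log units; within the scatter), so not every replacement of the 4-nitrophenyl pattern leaves the number in place. No supporting data are available that would explain the lower number of compound 3.

The change removes the nitro group and adds an amino group and a methoxy group in a single step, so the compounds shown do not separate the share of each. Also open, on these data alone, is whether a hydroxyl or an acetamide in place of the amino group would hold the lower number, or whether that number depends on the free amine.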